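Swapping 2-Cyanoethyl for Carboxy on a Level Baseline

A few compounds are considered here, and "the series" means these few. Any claim that something is new, unique, unknown or untested is made for them only; others in the source may bear on it.

In a functional assay on U-373MG ATCC cells for cytotoxicity against U373 MG (Homo sapiens), read by colorimetric assay and MTT assay (on this read-out higher numbers stand for weaker inhibition and lower numbers for stronger inhibition), compound 1 (`CCOC(=O)Cn1c(=O)c(-c2ccc(OC)cc2)cc2c(OC)cc(OC)cc21`) gives 10000 nM. Compound 2 (`COc1ccc(-c2cc3c(OC)cc(OC)cc3n(CCCC#N)c2=O)cc1`) gives 10000 nM, which places it level with compound 1. These two compounds share the same core and differ only in the group on the chain attached to an aromatic nitrogen. Among the measured compounds shown here, only one measured step connects them: no change at the digits printed from compound 1 to compound 2 (within the scatter).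

Compound 3 (`COc1ccc(-c2cc3c(OC)cc(OC)cc3n(CC(=O)O)c2=O)cc1`) has not yet been measured. It carries carboxy in place of 2-cyanoethyl on a saturated chain carbon bound to an aromatic nitrogen, a change counted as carboxy in place of 2-cyanoethyl on a saturated chain carbon bound to an aromatic nitrogen. For the measured compounds named here, this change falls at the same place on the molecule as the measured step, so that step is the only guide available. Going by the values given here, it is thin evidence, since it comes from a single pair, and no compound with a carboxy group has a measured value yet.

Since the guiding step showed no movement, no shift beyond the usual scatter is expected, and the estimated step is no change at the digits printed from compound 2 to compound 3 (within the scatter). For compound 3 the expected value is 10000 nM, with an estimated range from 5000 nM to 20000 nM.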

Compound 3, half-maximal inhibitory concentration: 10000 nM
Compound 3: middle estimate and measured number agree at the digits printed; low and high end bracket the measured number.
By their numbers in this assay, from the lowest: compounds 1, 2 and 3 (each within the scatter of the next).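

In this assay, a free carboxy group now joins the two earlier end groups on the chain at this aromatic nitrogen, and the step is no change at the digits printed from compound 2 to compound 3 (within the scatter). Hydrogen in place of ethyl on an oxygen next to a carbonyl group gives no change at the digits printed from compound 1 to compound 3 (within the scatter), so the ester and the free acid read alike here, a comparison that the first pair could not offer. Nothing measured here speaks to why the three compounds share one value.

The compounds shown therefore leave open whether any group at this position can move the value, since only the nitrile, the ester and the carboxylic acid appear there, while an amine, an amide or a plain alkyl chain on the same nitrogen would be further tests of it. They also leave open whether a change elsewhere, such as a hydroxy group in place of a methoxy group on the shared core, would give a different reading.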